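A second methyl group on compound 1

This account rests on a few compounds, and the source may have more. Where it says the series, first, only, none or still open, it means among the compounds named here.

Compound 1 `Cc1ccc(C(=O)Nc2sc3c(c2C(N)=O)CCCC3)cc1`: 450 nM
Compound 2 `CC(=O)c1ccc(C(=O)Nc2sc3c(c2C(N)=O)CCCC3)cc1`: 1800 nM

In a functional assay on MV4-11 cells (Homo sapiens) for antiproliferative activity (on this read-out lower numbers stand for stronger inhibition and higher numbers for weaker inhibition), compound 1 holds the lower of the two numbers. Compound 3 `Cc1ccc(C(=O)Nc2sc3c(c2C(N)=O)CCCC3)cc1C` differs from it by one change: methyl in place of hydrogen on an aromatic carbon, ortho to a methyl group. Among the measured compounds shown here, only one measured step is available, a 4.0-fold higher number from compound 1 to compound 2 (0.60 log units; beyond the scatter), a modest one with acetyl in place of methyl on an aromatic carbon. For the measured compounds named here, it bears only loosely, since no measured step adds a methyl group. No step beyond the scatter is therefore expected. The expected change is a 1.1-fold higher number from compound 1 to compound 3 (0.05 log units; within the scatter). For compound 3 the estimated value is 500 nM, with an expected range of 180 nM to 1400 nM.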

Compound 3, half-maximal inhibitory concentration: 710 nM
Compound 3: middle estimate off by 1.4-fold (0.15 log units), on the low side, and the stated range covers the measured number.
By their numbers in this assay, from the lowest: compounds 1 and 3 (each within the scatter of the next); then compound 2.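

Read in this assay, methyl in place of hydrogen on an aromatic carbon, ortho to a methyl group, gives a 1.6-fold higher number from compound 1 to compound 3 (0.20 log units; within the scatter) and so stays within the usual scatter. The earlier step replaced the methyl group of compound 1, whereas here that group stays and the ring gains a second methyl without a step beyond the scatter. No measurement at hand accounts for this result. The compounds shown leave open whether an ethyl group, an amine or a carboxylic acid at this same position would give a step beyond the scatter.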